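The source may report more compounds than this note shows. Statements on the series, on what has been measured and on what is new or still open speak of the compounds shown alone.

Measured compounds in a physicochemical assay for solubility, with a stated time of 18 h, at pH 7.4; on this read-out higher numbers stand for higher solubility and lower numbers for lower solubility:
compound 1, `COc1cccc(CNCCCNc2ccnc3cc(-c4ccccc4)ccc23)c1O`, 32000 nM
compound 2, `COc1cccc(CNCCCNc2ccnc3cc(Oc4ccc(C(C)(C)C)cc4)ccc23)c1O`, 14500 nM
compound 3, `COc1cccc(CNCCCNc2ccnc3cc(CC(C)C)ccc23)c1O`, 4200 nM

Compound 3 has the lowest number of the three in this assay; the nearest is compound 2, and the step of a 3.5-fold lower number from compound 2 to compound 3 (0.54 log units; beyond the scatter) lies beyond the scatter, as does a 7.6-fold lower number from compound 1 to compound 3 (0.88 log units; beyond the scatter). The pair of compounds 1 and 2 differs by a 2.2-fold lower number from compound 1 to compound 2 (0.34 log units; beyond the scatter).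

Compound 4, `COc1cccc(CNCCCNc2ccnc3cc(Cc4cc(C)cc(C)c4)ccc23)c1O`, is not yet measured. It differs from compound 3 by 3,5-dimethylphenyl in place of isopropyl on a saturated chain carbon bound to an aromatic carbon. Within the data shown here, the steps that bear on it are those ending at compound 3: a 7.6-fold lower number from compound 1 to compound 3 (0.88 log units; beyond the scatter) and a 3.5-fold lower number from compound 2 to compound 3 (0.54 log units; beyond the scatter). Both replace an aromatic ring on the aromatic carbon with isobutyl and both lower the number. Among the measured compounds shown here, compound 4 brings an aromatic ring back, though one bond further out and carrying two methyls, an arrangement none of the measured compounds shows. The direction is therefore uncertain; a small rise toward the numbers of compounds 1 and 2 seems somewhat more likely than a fall, but a step of only modest size is expected, a 1.3-fold higher number from compound 3 to compound 4 (0.12 log units; within the scatter). Compound 4 is estimated at 5500 nM, with a range of 1500 nM to 18000 nM.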

Compound 4, solubility: 4200 nM
Compound 4: middle estimate off by 1.3-fold (0.12 log units), on the high side, and the stated range covers the measured number.
By their numbers in this assay, from the lowest: compounds 3 and 4 (each within the scatter of the next); then compound 2; then compound 1.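

In this assay, no change at the digits printed from compound 3 to compound 4 (within the scatter), so 3,5-dimethylphenyl in place of isopropyl on a saturated chain carbon bound to an aromatic carbon leaves the read-out unmoved, even though the entering group has 8 heavy atoms against 3 and brings a six-membered aromatic ring. Compound 4 stands as far from the two earlier aryl-bearing compounds as compound 3 does, with a 3.5-fold lower number from compound 2 to compound 4 (0.54 log units; beyond the scatter) and a 7.6-fold lower number from compound 1 to compound 4 (0.88 log units; beyond the scatter), so among these four compounds an aromatic ring alone does not go with the higher numbers, and compound 4 is the compound that goes against that reading. No measurement in hand gives a reason for this flat step or for the gap to compound 1 and compound 2.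

Still open, as far as these compounds go, is whether the saturated carbon or the two methyl groups matter more in 3,5-dimethylbenzyl, since plain benzyl would separate them from the step to phenyl. Also open is how far this position can move the read-out with a ring bearing an amine or a carboxylic acid, as every group shown here is built from carbon, apart from the ether oxygen of 4-(tert-butyl)phenoxy.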